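A few compounds are considered here, and "the series" means these few. Any claim that something is new, unique, unknown or untested is made for them only; others in the source may bear on it.

Measured compounds in a functional assay on cells (Cancer cell lines, Homo sapiens) for cytotoxicity, read by sulforhodamine B assay, with a stated time of 48 h; on this read-out higher numbers stand for weaker inhibition of growth and lower numbers for stronger inhibition of growth:
compound 1 `COc1ccc(C2=NN(C3=NC(=O)/C(=C4\C(=O)Nc5ccc(Br)cc54)S3)C(c3ccc(OC)cc3)C2)cc1`: 240 nM
compound 2 `COc1ccc(C2=NN(C3=NC(=O)/C(=C4\C(=O)Nc5ccc(Cl)cc54)S3)C(c3ccc(OC)cc3)C2)cc1`: 230 nM
compound 3 `CN(C)c1ccc(C2CC(c3ccccc3)=NN2C2=NC(=O)/C(=C3\C(=O)Nc4ccc(Br)cc43)S2)cc1`: 250 nM

Compound 1 and compound 2 differ in one place, (chloro in place of bromo on an aromatic carbon); in this assay this gives a 1.0-fold lower number from compound 1 to compound 2 (0.02 log units; within the scatter). Compound 3 carries a different core from compound 1; the difference between the two cores is not broken down here. Compound 4 `CN(C)c1ccc(C2CC(c3ccccc3)=NN2C2=NC(=O)/C(=C3\C(=O)Nc4ccc(Cl)cc43)S2)cc1` is not yet measured. Among the measured compounds shown here, it differs from compound 3 by chloro in place of bromo on an aromatic carbon, the same change as the one from compound 1 to compound 2, at a place described in the same words. Given that the step from compound 1 to compound 2 was a 1.0-fold lower number from compound 1 to compound 2 (0.02 log units; within the scatter), the step from compound 3 to compound 4 in this assay is expected to be a 1.0-fold lower number from compound 3 to compound 4 (0.02 log units; within the scatter). Compound 4 is therefore estimated at 240 nM in this assay, with a range from 120 nM to 500 nM.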

Compound 4, concentration for 50% growth inhibition: 240 nM
The estimate for compound 4 equals the measured number at the digits printed, within the range that was stated.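

In this assay, chloro in place of bromo on an aromatic carbon gives a 1.0-fold lower number from compound 3 to compound 4 (0.02 log units; within the scatter). On the two cores shown, this change behaves alike, and neither step lies beyond the scatter: the same change on two cores in this assay, a 1.0-fold lower number (0.02 log units; within the scatter) from compound 1 to compound 2 and a 1.0-fold lower number (0.02 log units; within the scatter) from compound 3 to compound 4, 1.0-fold (0.00 log units) apart, within the scatter of two such steps

This supports carrying the bromo-to-chloro change between these two cores in this read-out, but it does not show that the match extends to other cores or other read-outs, and with steps this small it says nothing about why the two halogens match.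

The compounds shown leave open whether a different group at this place, such as fluoro, an amine or a carboxylic acid, would separate from bromo and chloro. They also leave open how such a group would carry between the two cores.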